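Aminobenzamide cap: phenyl for hydroxy on the shared core

A few compounds are considered here, and "the series" means these few. Any claim that something is new, unique, unknown or untested is made for them only; others in the source may bear on it.

Measured compounds:
- compound 1, `Nc1cc(O)ccc1NC(=O)c1ccc(CNc2nccc(-c3cccnc3)n2)cc1`: > 20000 nM
- compound 2, `Nc1ccccc1NC(=O)c1ccc(CNC2=NC[C@@H](c3ccccc3)S2)cc1`: 1400 nM
- compound 3, `Nc1ccccc1NC(=O)c1ccc(CNC2=N[C@@H](Cc3ccccc3)CS2)cc1`: 34900 nM

Of the compounds shown here, three have been tested in an assay for inhibition of histone deacetylase 8 (Homo sapiens), read by fluorescence, with stated times of 15 min and 60 min; on this read-out lower numbers stand for stronger inhibition and higher numbers for weaker inhibition. From the compounds shown here alone, for compound 1 the result is only a limit of this assay, not a number, so its true potency is unknown beyond that boundary; this is the situation described by the limit of > 20000 nM in this assay, at which 1 of the 3 values shown sits. Among the three, compound 1 therefore sits at the weak end of what the numbers can show, while compound 2 gives a measurable value and compound 3 gives a still weaker one.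

The unmeasured compound 4, `Nc1cc(-c2ccccc2)ccc1NC(=O)c1ccc(CNc2nccc(-c3cccnc3)n2)cc1`, is built from compound 1 by a single change: phenyl in place of hydroxy on an aromatic carbon. The hydroxy group leaves and a phenyl group enters at the same aromatic carbon.

Within the data shown here, no measured pair shows this exact change, so the step can only be guessed. Because compound 1 stands at > 20000 nM in this assay, any movement can only be read as a move into the measurable range. The step from compound 1 to compound 4 is expected to be an at least 2.5-fold lower number from compound 1 to compound 4 (0.39 log units; beyond the scatter), bringing the value below the limit but not into the strongest range seen. Compound 4 is thus estimated at 8000 nM, with a plausible range from 1500 nM to 40000 nM.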

Compound 4, half-maximal inhibitory concentration: > 20000 nM
Compound 4: a limit, no number; the forecaster's own chance of this, stated with the estimate: 35%; middle value at least 2.5-fold (0.39 log units) from the limit.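

In this assay compound 4 gives a limit and not a number (> 20000 nM). Among these compounds, compound 1 also gives a limit, so no step from compound 1 to compound 4 can be read: the limit of > 20000 nM in this assay, at which 2 of the 4 values shown sit. From the compounds shown here alone, whether phenyl in place of hydroxy changes inhibition on this core remains open.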